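Cytotoxicity on Vero cells: from compound 3 to compound 4

This account rests on a few compounds, and the source may have more. Where it says the series, first, only, none or still open, it means among the compounds named here.

Compound 1 `COc1ccc2[nH]c(C(=O)N3CC(=O)N(c4ccccc4)[C@@H](Cc4ccccc4)C3)cc2c1`: > 30000 nM in an ADME assay on Vero cells (Chlorocebus sabaeus) for cytotoxicity, with a stated time of 7 days (on this read-out higher numbers stand for lower toxicity in this test and lower numbers for higher toxicity in this test), a limit of the test.
Compound 2 `COc1ccc2[nH]c(C(=O)N3CC(=O)N(Cc4c[nH]c5ccccc45)[C@@H](Cc4ccccc4)C3)cc2c1`: 7200 nM in this assay.
Compound 3 `COc1ccc2[nH]c(C(=O)N3CC(=O)N(Cc4ccccc4)[C@@H](N4CCc5ccccc54)C3)cc2c1`: > 100000 nM in this assay, a limit of the test.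

Compound 3 stands at a limit, (the limit of > 100000 nM in this assay, at which 1 of the 3 values shown sits), so no number is known for it. Compound 4 `COc1ccc2[nH]c(C(=O)N3CC(=O)N(Cc4ccccc4)[C@@H](CN4CCC5(CCCC5)CC4)C3)cc2c1` differs from compound 3 by a group of 11 heavy atoms (10 carbon, 1 nitrogen; one five-membered non-aromatic ring of carbon only, one six-membered non-aromatic ring with 1 hetero atom) in place of a group of 9 heavy atoms (8 carbon, 1 nitrogen; one five-membered non-aromatic ring with 1 hetero atom, one six-membered aromatic ring of carbon only), on a saturated ring carbon. Among the measured compounds shown here, the one measured step, an at least 4.1-fold lower number from compound 1 to compound 2 (0.61 log units; beyond the scatter), concerns a change on the amide-type nitrogen, not on the saturated ring carbon, and compound 1 itself sits at a limit, (the limit of > 30000 nM in this assay, at which 1 of the 3 values shown sits); no step bears directly on this change. No direction beyond the scatter is therefore expected for an at least 2.0-fold lower number from compound 3 to compound 4 (0.30 log units; that floor lies within the scatter). Compound 4 is estimated at 50000 nM, within 10000 nM to 100000 nM, with a fair chance that only a limit is reported.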

Compound 4, half-maximal cytotoxic concentration: 3600 nM
Beside the measured number, compound 4's estimate is 14-fold (1.14 log units) above it; measured number outside the range, below it.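

Until now only a change on the amide-type nitrogen had moved the read-out in this assay; on the saturated ring carbon, the group of 11 heavy atoms in place of 2,3-dihydro-1H-indol-1-yl gives an at least 27-fold lower number from compound 3 to compound 4 (1.44 log units; beyond the scatter) in this single pair. That size is only a floor, because compound 3 stands at a limit of the test: the limit of > 100000 nM in this assay, at which 1 of the 4 values shown sits.

The two groups differ in more than one feature, and the compounds shown do not tell which feature goes with the lower number. Going by these compounds, how a piperidin-1-ylmethyl or a dimethylaminomethyl group would read on this carbon remains open.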